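The source may report more compounds than this note shows. Statements on the series, on what has been measured and on what is new or still open speak of the compounds shown alone.

Measured compounds:
compound 1 `COc1cc2ncnc(N3CCCc4ccccc43)c2cc1NC(=O)/C=C/CN(C)C` — 1650 nM
compound 2 `COc1cc2ncnc(N3CCCc4ccccc43)c2cc1NC(=O)/C=C/CN1CCCC1` — 2230 nM

Both were tested in a functional assay on A549 cells (Homo sapiens) for antiproliferative activity, read by MTT assay, with a stated time of 72 h; on this read-out higher numbers stand for weaker inhibition and lower numbers for stronger inhibition. Of the two numbers, compound 2 gives the higher one, but the gap to compound 1 is small: a 1.4-fold higher number from compound 1 to compound 2 (0.13 log units; within the scatter). Among the compounds with values here, that single step, an exchange of one amine for a ring amine at the same place, is the only guide available here.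

Compound 3 `COc1cc2ncnc(N3CCCc4ccccc43)c2cc1NC(=O)/C=C/CN1CCCCC1` carries the next change at the same position: piperidin-1-yl in place of pyrrolidin-1-yl on a saturated chain carbon bound to a double-bonded chain carbon. Within the data shown here, the one comparable step, from compound 1 to compound 2, stayed within the scatter, so the expectation for compound 3 is again a change of no clear size in either direction, at most a slight drift toward a higher number. The estimated step is a 1.1-fold higher number from compound 2 to compound 3 (0.05 log units; within the scatter).

On that basis compound 3 is expected to give about 2500 nM in this assay, with a likely range from 1100 nM to 6000 nM.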

Compound 3, half-maximal inhibitory concentration: 2880 nM
For compound 3 the middle estimate is 1.2-fold (0.06 log units) below the measured one; the range from low to high includes it.
By their numbers in this assay, from the lowest: compounds 1, 2 and 3 (each within the scatter of the next).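

In this assay, this position on a saturated chain carbon bound to a double-bonded chain carbon accepts a six-membered ring amine as well as a five-membered one: replacing pyrrolidin-1-yl with piperidin-1-yl gives a 1.3-fold higher number from compound 2 to compound 3 (0.11 log units; within the scatter). Set against the open-chain dimethylamino group, piperidin-1-yl gives a 1.7-fold higher number from compound 1 to compound 3 (0.24 log units; within the scatter), so all three amines tested here lie within the usual scatter of one another, and none can be ranked above the others. No accompanying measurement offers an explanation for these numbers.

The compounds shown leave open whether a ring amine with a second hetero atom, such as morpholin-4-yl or 4-methylpiperazin-1-yl, would also stay within that scatter. They also leave open what would follow if the amine were replaced by a group with no nitrogen, such as a methoxy group.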